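The compounds below may be only part of what the source reports. "The series", "measured", "known", "first", "only" and "open" are said of these compounds alone.

Measured compounds:
- compound 1, `CCCN(CCC)c1nc(C(F)(F)F)ccc1CNC(=O)Nc1cccc2[nH]c(=O)ccc12`: 5.21 nM
- compound 2, `CC(C)COc1nc(C(F)(F)F)ccc1CNC(=O)Nc1cccc2[nH]c(=O)ccc12`: 2.6 nM
- compound 3, `O=C(NCc1ccc(C(F)(F)F)nc1OCC1CCC1)Nc1cccc2[nH]c(=O)ccc12`: 1.49 nM

All three share one core and differ only in the group on an aromatic carbon of the pyridine. In an assay on HEK cells for antagonist activity at transient receptor potential cation channel subfamily V member 1 (Homo sapiens), read by FLIPR (a higher number here means a weaker inhibitor, a lower number a stronger inhibitor), compound 1 gives 5.21 nM, the highest of the three numbers. Its nearest neighbour is compound 2, a 2.0-fold lower number from compound 1 to compound 2 (0.30 log units; within the scatter), and the furthest is compound 3, a 3.5-fold lower number from compound 1 to compound 3 (0.54 log units; beyond the scatter). Between the two ethers the gap is small: a 1.7-fold lower number from compound 2 to compound 3 (0.24 log units; within the scatter).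

Compound 4, `O=C(NCc1ccc(C(F)(F)F)nc1-c1ccc(F)cc1)Nc1cccc2[nH]c(=O)ccc12`, has not yet been measured in this assay. It differs from compound 1 in one place: 4-fluorophenyl in place of dipropylamino on an aromatic carbon. The measured steps that bear on this change are those leaving dipropylamino, a 2.0-fold lower number from compound 1 to compound 2 (0.30 log units; within the scatter) and a 3.5-fold lower number from compound 1 to compound 3 (0.54 log units; beyond the scatter); each puts an oxygen-linked group where the dipropylamino stood and each gives a lower number, one within the scatter and one modestly beyond it. Going by the values given here, no measured step puts an aromatic ring at this position, so the pair of steps shows only that the dipropylamino group can be exchanged without loss, not what an aromatic substituent does. The expectation for compound 4 is therefore a step of a 1.2-fold higher number from compound 1 to compound 4 (0.06 log units; within the scatter), with no firm direction beyond the scatter. Compound 4 is estimated at 6 nM, with a range from 1.5 nM to 25 nM.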

Compound 4, half-maximal inhibitory concentration: 1.93 nM
For compound 4 the middle estimate is 3.1-fold (0.49 log units) above the measured one, and the stated range covers the measured number.
By their numbers in this assay, from the lowest: compounds 3, 4, 2 and 1 (each within the scatter of the next, the first and the last beyond it).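

The result shows that this position, on an aromatic carbon next to the ring nitrogen, accepts an aromatic ring as well as the oxygen-linked chains: in this assay, 4-fluorophenyl in place of dipropylamino gives a step beyond the scatter (a 2.7-fold lower number from compound 1 to compound 4 (0.43 log units; beyond the scatter)). Exchanging either ether for the 4-fluorophenyl group leaves the number within the scatter (a 1.3-fold higher number from compound 3 to compound 4 (0.11 log units; within the scatter); a 1.3-fold lower number from compound 2 to compound 4 (0.13 log units; within the scatter)), so among these compounds, the oxygen link and the chain are not needed for a low number, and a one-ring group of carbon only serves as well as the isobutoxy and cyclobutylmethoxy groups. The data shown offer nothing that explains why these three groups give such close numbers, or why each sits lower than dipropylamino.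

From the compounds shown here alone, what a plain phenyl or a 4-chlorophenyl group would give here remains open, and with it whether the fluorine contributes at all, as does the outcome with a pyridyl ring in its place. Also open, going by these compounds, is how far the group can shrink or change, from a methyl group to a cyclic amine such as piperidine or morpholine.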